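The compounds below may be only part of what the source reports. "The series", "measured", "known", "first", "only" and "open" are said of these compounds alone.

Three compounds sharing one core were measured in a functional assay on HeLa cells (Homo sapiens) for antiproliferative activity, read by MTT assay, with a stated time of 24 h; on this read-out higher numbers stand for weaker inhibition and lower numbers for stronger inhibition:

compound 1 `Clc1cccc(CSc2nnc(-c3ccc4c(c3)OCCO4)n2-c2ccccc2)c1`: 15000 nM
compound 2 `Fc1ccccc1CSc1nnc(-c2ccc3c(c2)OCCO3)n1-c1ccccc1`: 24300 nM
compound 3 `Fc1cccc(F)c1CSc1nnc(-c2ccc3c(c2)OCCO3)n1-c1ccccc1`: 35200 nM

Compound 3 lies at the upper end of this small set, though not clearly apart from compound 2: the gap is a 1.4-fold higher number from compound 2 to compound 3 (0.16 log units; within the scatter). Among the compounds with values here, it is separated from compound 1 by a 2.3-fold higher number from compound 1 to compound 3 (0.37 log units; beyond the scatter), the only step here that clears the scatter, and a modest one.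

Compound 4 `Brc1ccccc1CSc1nnc(-c2ccc3c(c2)OCCO3)n1-c1ccccc1` is still unmeasured. It differs from compound 3 by 2-bromophenyl in place of 2,6-difluorophenyl on a saturated chain carbon bound to a sulfur, with 2-bromophenyl in place of 2,6-difluorophenyl on a saturated chain carbon bound to a sulfur.

Within the data shown here, no measured compound carries bromine, so the evidence is indirect. The nearest comparison is compound 2, whose 2-fluorophenyl also has a single halogen, and adding a fluoro to it gave a 1.4-fold higher number from compound 2 to compound 3 (0.16 log units; within the scatter). Exchanging the halogen-bearing ring gave a 1.6-fold higher number from compound 1 to compound 2 (0.21 log units; within the scatter), also small. Steps of this size suggest a slightly lower number for compound 4 than for compound 3, with no change expected beyond the scatter.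

The step expected is a 1.7-fold lower number from compound 3 to compound 4 (0.22 log units; within the scatter).

The estimated value for compound 4 is 21000 nM, with an expected range of 11000 nM to 39000 nM.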

Compound 4, half-maximal inhibitory concentration: > 100000 nM
Compound 4 gave a limit, no number; the forecaster's own chance of this, stated with the estimate: 4%; middle value at least 4.7-fold (0.67 log units) from the limit.
By their numbers in this assay, from the lowest: compounds 1, 2 and 3 (each within the scatter of the next, the first and the last beyond it). At a limit, above all of these: compound 4.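

At this place, on a saturated chain carbon bound to a sulfur, the three earlier halogen-bearing phenyl groups differed by no more than a modest step, so they gave no sign that a single exchange could move the read-out further. Compound 4 shows that it can: bromo in place of fluoro gives the largest step that can be read for a single atom exchange here (an at least 4.1-fold higher number from compound 2 to compound 4 (0.61 log units; beyond the scatter)), and 2-bromophenyl also stands clearly apart from 2,6-difluorophenyl (an at least 2.8-fold higher number from compound 3 to compound 4 (0.45 log units; beyond the scatter)) and from 3-chlorophenyl (an at least 6.6-fold higher number from compound 1 to compound 4 (0.82 log units; beyond the scatter)), each step beyond the scatter and each only a lower bound. In this assay compound 4 gives a limit and not a number, so the full size of these steps stays unknown: the limit of > 100000 nM in this assay, at which 1 of the 4 values shown sits.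

The compounds shown leave open whether this loss belongs to bromo itself or would also follow from a chloro, an iodo or a methyl on the same phenyl ring. They also leave open how an amine or a carboxylic acid on that ring would read, and whether bromo would have the same consequence with a longer chain in place of the benzyl carbon.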